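Swapping the carbamate cap on compound 1 for tert-butyl

The source may report more compounds than this note shows. Statements on the series, on what has been measured and on what is new or still open speak of the compounds shown alone.

Three measured compounds share one core and differ only in the group hanging from the triazole nitrogen. Compound 1 `O=C(OCc1ccccc1)N1CCN(C(=S)SCc2cn(Cc3ccc(Cl)cc3)nn2)CC1` carries a 4-chlorophenyl there; in a functional assay on MCF7 cells (Homo sapiens) for inhibition, read by MTT assay, with a stated time of 72 h (on this read-out lower numbers stand for stronger inhibition and higher numbers for weaker inhibition), compound 1 gives 27500 nM, the highest of the two numbers reported. Compound 2 `O=C(OCc1ccccc1)N1CCN(C(=S)SCc2cn(Cc3ccccc3F)nn2)CC1` carries a 2-fluorophenyl instead, and in this assay compound 2 gives 7950 nM; the change is a 3.5-fold lower number from compound 1 to compound 2 (0.54 log units; beyond the scatter). Compound 3 `COc1cc(Cn2cc(CSC(=S)N3CCN(C(=O)OCc4ccccc4)CC3)nn2)cc(OC)c1OC` carries a 3,4,5-trimethoxyphenyl, and for compound 3 this assay reports only a limit, > 128000 nM. From this follow an at least 4.6-fold higher number from compound 1 to compound 3 (0.66 log units; beyond the scatter) and an at least 16-fold higher number from compound 2 to compound 3 (1.20 log units; beyond the scatter); the limit of > 128000 nM in this assay, at which 1 of the 3 values shown sits, bounds what those steps can show.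

Compound 4 `CC(C)(C)OC(=O)N1CCN(C(=S)SCc2cn(Cc3ccc(Cl)cc3)nn2)CC1` keeps the 4-chlorophenyl of compound 1 and changes the other end of the molecule: tert-butyl in place of benzyl on an oxygen next to a carbonyl group. None of the three measured steps touches this carbamate position; all of them move the group on the triazole nitrogen, and two of them run into the limit. Among the measured compounds shown here, there is therefore no measured precedent for the step from compound 1 to compound 4, and the expected outcome is no change beyond the scatter, no change at the digits printed from compound 1 to compound 4 (within the scatter). Compound 4 is accordingly estimated at 27500 nM, with a plausible range from 9000 nM to 90000 nM.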

Compound 4, half-maximal inhibitory concentration: 2960 nM
Beside the measured number, compound 4's estimate is 9.3-fold (0.97 log units) above it, and the stated range ends above it.
By their numbers in this assay, from the lowest: compound 4; then compound 2; then compound 1. At a limit, above all of these: compound 3.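

Among the compounds shown here, the carbamate end of the molecule proves to be far from silent: in this assay, tert-butyl in place of benzyl on an oxygen next to a carbonyl group gives a 9.3-fold lower number from compound 1 to compound 4 (0.97 log units; beyond the scatter), a change made without touching the group on the triazole nitrogen that all the earlier steps varied. The result also shows that, with the 4-chlorophenyl in place, the six-membered aromatic ring of the benzyl is not required for a measurable reading in this assay, since tert-butyl has no ring and fewer heavy atoms, yet compound 4 has the lowest number of the series. No available measurement explains why this swap lowers the number.

From the compounds shown here alone, this is a single pair, so it remains open whether tert-butyl would lower the number in the same way with the 2-fluorophenyl of compound 2 on the triazole nitrogen. Going by these compounds, it also remains open whether the result depends on the branching of tert-butyl or simply on the loss of the aromatic ring, a question that a methyl, an ethyl or a cyclohexyl on the same oxygen could help to answer.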